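Exchanging the Phenyl Group on the Nitrogen

This account rests on a few compounds, and the source may have more. Where it says the series, first, only, none or still open, it means among the compounds named here.

Compound 1 `COc1cc(N(CC2CC2)c2ccccc2)cnc1C(=O)[C@H]1C[C@@H]1C(=O)O` and compound 2 `COc1cc(N(CC2CC2)c2cccc(C(F)(F)F)c2)cnc1C(=O)[C@H]1C[C@@H]1C(=O)O` share a core and differ only in the phenyl group on a nitrogen on an aromatic ring. In an ADME assay on cells (Hepatocyte, Homo sapiens) for metabolic stability, read by LC-MS, with a stated time of 60 min, tested at 1 uM (on this read-out lower numbers stand for slow clearance and higher numbers for fast clearance), compound 1 gives 3 uL/min and compound 2 gives 2.3 uL/min. Within the data shown here, the one measured step, a 1.3-fold lower number from compound 1 to compound 2 (0.12 log units; within the scatter), came from putting trifluoromethyl in place of hydrogen on an aromatic carbon and falls within the scatter. Compound 2 thus stands at one of two numbers that lie within the scatter of each other, so the two compounds cannot be told apart; both are cleared slowly.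

Compound 3 `COc1cc(N(CC2CC2)c2ccc(F)c(Cl)c2)cnc1C(=O)[C@H]1C[C@@H]1C(=O)O` has not yet been measured. It differs from compound 2 in one place: 3-chloro-4-fluorophenyl in place of 3-(trifluoromethyl)phenyl on a nitrogen on an aromatic ring. Among the measured compounds shown here, the only step that bears on this change is a 1.3-fold lower number from compound 1 to compound 2 (0.12 log units; within the scatter), which shows that altering the group on this phenyl ring did not move the number beyond the scatter. For the measured compounds named here, no measured step covers chlorine and fluorine on this ring, so no direction can be read from the data. For compound 3 the expected step is a 1.1-fold higher number from compound 2 to compound 3 (0.05 log units; within the scatter), meaning no change beyond the scatter. The estimate for compound 3 in this assay is 2.6 uL/min, with a range from 1.2 uL/min to 5.5 uL/min.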

Compound 3, intrinsic clearance in a liver preparation (reported as CLH), per the amount of preparation that the assay uses: 3.1 uL/min
Compound 3: middle estimate off by 1.2-fold (0.08 log units), on the low side; low and high end bracket the measured number.
By their numbers in this assay, from the lowest: compounds 2, 1 and 3 (each within the scatter of the next).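

In this assay, exchanging one substituted ring for another gives a 1.3-fold higher number from compound 2 to compound 3 (0.13 log units; within the scatter) and exchanging the unsubstituted phenyl for the chlorine and fluorine pair gives a 1.0-fold higher number from compound 1 to compound 3 (0.01 log units; within the scatter) and so neither step can be told apart from the ordinary variation between repeated measurements. Until now the only substituent seen on this ring was trifluoromethyl, whereas phenyl, 3-(trifluoromethyl)phenyl and 3-chloro-4-fluorophenyl on this nitrogen now all give numbers within the scatter of one another, so in these three compounds this position accepts two different substituted rings and clearance stays slow throughout. No supporting measurement is available to explain why the three numbers stay together.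

All three rings shown carry only carbon and halogen substituents, so it remains open what an amine, a hydroxyl group or a nitrile on this ring would do to the clearance number. From the compounds shown here alone, it also remains open whether a longer saturated chain in place of the ring on this nitrogen would keep the number in the same range.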